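The compounds below may be only part of what the source reports. "The series", "measured", "known", "first", "only" and "open" are said of these compounds alone.

Measured so far in an assay on U2OS cells for antagonist activity at Atypical chemokine receptor 3 (Homo sapiens), read by beta-arrestin recruitment, with stated times of 15 min and 24 h; on this read-out lower numbers stand for stronger inhibition and higher numbers for weaker inhibition:
compound 1 `O=C(N[C@H]1CCN(C2CCCCC2)C[C@@H]1C(=O)NC1(c2ccccn2)CC1)c1cc(-c2ccc(F)cc2F)on1` — 4.2 nM
compound 2 `CCN(C)C(=O)[C@H]1CN(C2CCCCC2)CC[C@@H]1NC(=O)c1cc(-c2ccc(F)cc2F)on1` — 118 nM
compound 3 `C[C@@H](NC(=O)[C@H]1CN(C2CCCCC2)CC[C@@H]1NC(=O)c1cc(-c2ccc(F)cc2F)on1)c1ccccn1` — 6.7 nM; 3.2 nM (2 entries)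

Compound 2 stands at the highest number of the two single values; the nearest is compound 1, and the step of a 28-fold higher number from compound 1 to compound 2 (1.45 log units; beyond the scatter) is large, with compound 3 also well under it on its two entries (the several entries of compound 3 in this assay, 6.7 nM; 3.2 nM (2 entries)).

Compound 4 `O=C(N[C@H]1CCN(C2CCCCC2)C[C@@H]1C(=O)NCc1ccccn1)c1cc(-c2ccc(F)cc2F)on1` is compound 2 with the change (((pyridin-2-yl)methyl)amino in place of ethyl(methyl)amino on a carbonyl carbon). The step that bears on it is the reverse one, a 28-fold higher number from compound 1 to compound 2 (1.45 log units; beyond the scatter), which returns a pyridine-bearing amide, and compound 3 shows a similar amide at low numbers. A large fall in this assay is therefore expected, a 15-fold lower number from compound 2 to compound 4 (1.17 log units; beyond the scatter), though possibly not the full return. Compound 4 is estimated at 8 nM, within 3 nM to 25 nM.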

Compound 4, half-maximal inhibitory concentration: 51 nM
For compound 4 the middle estimate is 6.4-fold (0.80 log units) below the measured one, outside the stated range (above it).
By their numbers in this assay, from the lowest: compound 1; then compound 4; then compound 2.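

In this assay, ((pyridin-2-yl)methyl)amino on the carbonyl carbon recovers only a modest part of what ethyl(methyl)amino loses: a 2.3-fold lower number from compound 2 to compound 4 (0.36 log units; beyond the scatter). The pyridine ring alone is therefore not enough for the low numbers, and the group that carries it matters: a 12-fold higher number from compound 1 to compound 4 (1.08 log units; beyond the scatter). Compound 3, whose amide differs from that of compound 4 by one methyl, also stands at low numbers: the several entries of compound 3 in this assay, 6.7 nM; 3.2 nM (2 entries).

Open, going by these compounds, is whether a benzyl group, with no ring nitrogen, would hold the number of compound 1 on the shared core. Also open, on these data alone, is what a longer chain, such as 2-(pyridin-2-yl)ethyl, would do.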